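A few compounds are considered here, and "the series" means these few. Any claim that something is new, unique, unknown or untested is made for them only; others in the source may bear on it.

The series shares one core and varies the group on the oxygen that links two aromatic rings. Compound 1 `Cc1cn(C2CCN(Cc3cccc(Oc4cc(Cl)cc(Cl)c4)c3)CC2)c(=O)[nH]c1=O` carries a dichlorophenyl there, and in an ADME assay on MRC5 cells (Homo sapiens) for cytotoxicity, read by fluorescence and resazurin assay, with a stated time of 3 days (on this read-out higher numbers stand for weaker inhibition and lower numbers for stronger inhibition), compound 1 gives 6730 nM. Within the data shown here, compound 2 `Cc1cn(C2CCN(Cc3cccc(Oc4ccccc4)c3)CC2)c(=O)[nH]c1=O`, the unsubstituted phenyl analogue, has in this assay only the entry "not determined" (no result reported), so no number stands for it and no measured step exists within the set. Compound 3 `Cc1cn(C2CCN(Cc3cccc(Oc4ccc(Cl)c(C(F)(F)F)c4)c3)CC2)c(=O)[nH]c1=O` differs from compound 2 by 4-chloro-3-(trifluoromethyl)phenyl in place of phenyl on an oxygen on an aromatic ring. Among the measured compounds shown here, with no measured step to anchor the change, the only reference is compound 1, whose value of 6730 nM came from a comparably substituted phenyl. Compound 3 is therefore expected to land near compound 1, with any movement likely no larger than the usual scatter. Compound 3 is estimated at 6000 nM in this assay, with a range from 2500 nM to 15000 nM.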

Compound 3, half-maximal inhibitory concentration: 5280 nM
Estimate against measurement, compound 3: 1.1-fold (0.06 log units) above, and the stated range covers the measured number.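

In this assay, putting 4-chloro-3-(trifluoromethyl)phenyl in place of 3,5-dichlorophenyl on an oxygen on an aromatic ring gives a 1.3-fold lower number from compound 1 to compound 3 (0.11 log units; within the scatter). Among these compounds, this is the first measured step at this position, and it shows that these two halogen-bearing phenyl groups cannot be told apart on this read-out, even though they differ in both their substituents and where these stand on the ring. The data offer no measured explanation for this likeness.

Going by these compounds, how the unsubstituted phenyl of compound 2 compares with these two groups stays open, so the effect of having any substituent on this ring cannot be judged. On these data alone, it also remains open whether the read-out would hold with an amine or a carboxylic acid on this ring.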